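The source may hold more compounds than are shown below. What is called first, only, known or untested is meant among the compounds shown, and "the series" means these compounds.

In a functional assay on HCT-116 cells (Homo sapiens) for antiproliferative activity, read by MTT assay, with a stated time of 72 h (on this read-out lower numbers stand for stronger inhibition of growth and higher numbers for weaker inhibition of growth), compound 1 `Cn1nc(-c2ccnc(Nc3ccc(O)cc3)n2)c2ccccc21` gives 8430 nM. Among the measured compounds shown here, of the two numbers measured so far none is lower than it, yet its only neighbour, compound 2 `Cn1nc(-c2ccnc(Nc3cccc(Cl)c3)n2)c2ccccc21` with 6400 nM, sits within the scatter, as the step of a 1.3-fold lower number from compound 1 to compound 2 (0.12 log units; within the scatter) shows. Compound 3 `CCCn1nc(-c2ccnc(Nc3ccc(O)cc3)n2)c2ccccc21` differs from compound 1 by ethyl in place of hydrogen on a saturated chain carbon bound to an aromatic nitrogen. For the measured compounds named here, the single measured step changed a different part of the shared core and was itself small, so no measured step bears on this change, and no shift beyond the scatter is expected in this assay. Compound 3 is therefore estimated at 8000 nM, between 3000 nM and 20000 nM. The expected step is a 1.1-fold lower number from compound 1 to compound 3 (0.02 log units; within the scatter).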

Compound 3, concentration for 50% growth inhibition: 5450 nM
Compound 3: the middle estimate sits 1.5-fold (0.17 log units) above what was measured; low and high end bracket the measured number.
By their numbers in this assay, from the lowest: compounds 3, 2 and 1 (each within the scatter of the next).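

Going from methyl to propyl on the aromatic nitrogen is the only change at this position shown so far, and in this assay it stays within the scatter (a 1.5-fold lower number from compound 1 to compound 3 (0.19 log units; within the scatter)). This position therefore carries the added ethyl with no clear shift in growth inhibition in either direction. No measured evidence offers an explanation for this result.

A single step cannot show a trend along the chain. From the compounds shown here alone, how a longer chain such as butyl, or a chain ending in an amine or a carboxylic acid, would read in this assay remains open.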